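The compounds below may be only part of what the source reports. "The series", "measured", "known", "first", "only" and "open" are said of these compounds alone.

Working notes on the series in an ADME assay on Akata cells (Homo sapiens) for cytotoxicity; on this read-out lower numbers stand for higher toxicity in this test and higher numbers for lower toxicity in this test. Compound 1 `Nc1nc2c(ncn2/C=C2\C[C@@H]2[C@H](O)CO)c(=O)[nH]1` gives 67000 nM, compound 3 `Nc1nc2c(ncn2/C=C2/C[C@H]2[C@H](O)CO)c(=O)[nH]1` gives 62600 nM, and compound 2 `Nc1ncnc2c1ncn2/C=C1\C[C@H]1[C@H](O)CO` gives 72700 nM, so compound 2 stands level with both within the scatter. The next comparison is with compound 4 `Nc1ncnc2c1ncn2/C=C1/C[C@@H]1[C@@H](O)CO`: the two compounds have the same atoms and bonds and differ only in configuration as drawn: 3 of 3 stereo elements differ; a stereocentre at a saturated ring carbon is drawn R in compound 2 and S in compound 4; a stereocentre at a saturated chain carbon is drawn S in compound 2 and R in compound 4; a double bond is drawn E in compound 2 and Z in compound 4. Among the measured compounds shown here, the only measured step that bears on this is a 1.1-fold lower number from compound 1 to compound 3 (0.03 log units; within the scatter), which lies within the scatter and also changes a ring stereocentre and the double bond. For the measured compounds named here, no measured step changes the chain stereocentre, so that part of the change remains untested. An estimated 1.1-fold lower number from compound 2 to compound 4 (0.05 log units; within the scatter) is therefore expected, with no shift beyond the scatter. For compound 4 the expected value is 65000 nM, with an estimated range of 30000 nM to 130000 nM.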

Compound 4, half-maximal cytotoxic concentration: 55000 nM
Compound 4: middle estimate off by 1.2-fold (0.07 log units), on the high side, within the range that was stated.
By their numbers in this assay, from the lowest: compounds 4, 3, 1 and 2 (each within the scatter of the next).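

In this assay, among the compounds shown here, a 1.3-fold lower number from compound 2 to compound 4 (0.12 log units; within the scatter) stays within the scatter, and this is the first step that includes the chain stereocentre, changed here together with the ring stereocentre and the double bond. Configuration as drawn is thus the only difference in this pair, and the full change of all three stereo elements shifts the number no further than the scatter: the fact that compounds 2 and 4 differ only in the configuration as drawn

From the compounds shown here alone, the contribution of each stereo element alone remains open, since this step changes them together. Also open, going by these compounds, is how a longer chain, an amine or a carboxylic acid on the side chain would read in this assay.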